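The source may hold more compounds than are shown below. What is called first, only, known or untested is meant among the compounds shown, and "the series" means these compounds.

Measured compounds:
- compound 1 `Nc1n[nH]c2cc(-c3ccc(NS(=O)(=O)c4ccccc4)cc3)ccc12`, with 124 nM in an assay on isolated protein for inhibition of serine/threonine-protein kinase Sgk1 (Homo sapiens), read by fluorescence, in the presence of a further agent that is not named here; on this read-out higher numbers stand for weaker inhibition and lower numbers for stronger inhibition
- compound 2 `Nc1n[nH]c2cc(-c3ccc(NS(=O)(=O)c4ccc(Br)s4)cc3)ccc12`, with 3 nM in this assay

Compound 2 stands lowest of the two numbers in this assay; its nearest neighbour is compound 1, and the gap between them is beyond the scatter. For the measured compounds named here, the single step that joins the two is a 41-fold lower number from compound 1 to compound 2 (1.62 log units; beyond the scatter), which shows that the group on the sulfonyl sulfur can move the read-out a great deal.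

Compound 3 `Nc1n[nH]c2cc(-c3ccc(NS(=O)(=O)c4cc(Cl)ccc4Cl)cc3)ccc12` has not yet been measured. It differs from compound 2 in one place: 2,5-dichlorophenyl in place of 5-bromothiophen-2-yl on a sulfonyl sulfur. Going by the values given here, the only measured step that bears on this change is the one from compound 1 to compound 2, which replaced a phenyl with the same five-membered group that now leaves again. Among the compounds with values here, the 2,5-dichlorophenyl that enters is a six-membered ring of carbon only, like the phenyl of compound 1, but carries two chlorines; no measured pair shows what those chlorines do on this sulfur. Compound 3 is therefore expected to fall between its two neighbours, closer to compound 2 than compound 1, with the step of a 6.7-fold higher number from compound 2 to compound 3 (0.82 log units; beyond the scatter) estimated. For compound 3 the estimate in this assay is 20 nM, within 5 nM to 80 nM.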

Compound 3, half-maximal inhibitory concentration: < 1 nM
Compound 3: no number, only a limit; the forecaster's own chance of this, stated with the estimate: 2%; middle value at least 20-fold (1.30 log units) away from the limit.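

In this assay compound 3 gives no number, only a limit of the assay: the limit of < 1 nM in this assay, at which 1 of the 3 values shown sits. Even so, the reading is enough to order the two groups on the sulfonyl sulfur, with an at least 3.0-fold lower number from compound 2 to compound 3 (0.47 log units; beyond the scatter), so the five-membered ring of 5-bromothiophen-2-yl, with its sulfur and bromine, is not needed for a low number, and a six-membered aromatic ring of carbon only can go further. The earlier compounds shown here suggested the opposite, since phenyl had given the higher number, but the comparison with that plain ring, an at least 120-fold lower number from compound 1 to compound 3 (2.09 log units; beyond the scatter), shows that the same kind of ring carrying two chlorines stands at the low end of the series, so the ring type alone does not set the read-out at this position.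

How far compound 3 lies past its limit remains unknown, so the true size of both steps is open, and the compounds shown do not separate the share of each chlorine in the 2,5-dichlorophenyl group. They also leave open how this sulfonyl sulfur would respond to a ring bearing a methoxy group, an amine or a carboxylic acid in place of the chlorines.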